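Dropping the Chloro Group: From Compound 1 to Compound 4

This account rests on a few compounds, and the source may have more. Where it says the series, first, only, none or still open, it means among the compounds named here.

Of the compounds shown here, three sharing one core have been measured in a functional assay on U-251 cells (Homo sapiens) for inhibition; a lower number here means a stronger inhibitor of growth, a higher number a weaker inhibitor of growth. Compound 1 `COc1cc(/C=C/C(=O)c2cccc(-n3cc(-c4ccc(Cl)cc4)[nH]c3=O)c2)cc(OC)c1OC` gives 2120 nM, the highest number of the three. Compound 2 `COc1cc(/C=C/C(=O)c2cccc(-n3cc(-c4ccccc4)[nH]c3=O)c2)ccc1O` gives 2110 nM in this assay, a number that lies within the scatter of compound 1, so the two cannot be told apart. Among the compounds with values here, compound 3 `O=C(/C=C/c1cccc(O)c1)c1cccc(-n2cc(-c3ccc(Cl)cc3)[nH]c2=O)c1` gives 580 nM, a lower number than compound 1 by a margin beyond the scatter; the two differ in more than one place, so only this pair of values can be stated. Compound 4 `COc1cc(/C=C/C(=O)c2cccc(-n3cc(-c4ccccc4)[nH]c3=O)c2)cc(OC)c1OC` has not yet been measured. It differs from compound 1 in one place: hydrogen in place of chloro on an aromatic carbon. Since compounds 1 and 2 carry different groups on this aromatic carbon yet give numbers within the scatter of each other, while also differing elsewhere, no change beyond the scatter is expected from compound 1 to compound 4, and the step of a 1.2-fold higher number from compound 1 to compound 4 (0.07 log units; within the scatter) is estimated to stay within it. Compound 4 is therefore expected to give 2500 nM in this assay, with a range from 1000 nM to 6500 nM.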

Compound 4, concentration for 50% growth inhibition: 630 nM
Compound 4: the middle estimate sits 4.0-fold (0.60 log units) above what was measured; the whole stated range lies above it.
By their numbers in this assay, from the lowest: compounds 3 and 4 (each within the scatter of the next); then compounds 2 and 1 (each within the scatter of the next).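

In this assay, replacing chloro with hydrogen on this aromatic carbon, para to a large group, gives a 3.4-fold lower number from compound 1 to compound 4 (0.53 log units; beyond the scatter). This is the first pair shown that differs in this place alone, and it shows that the change from 4-chlorophenyl to phenyl alters the number by more than the scatter, with the chloro compound giving the higher number. Nothing shown accounts for this step.

The compounds shown leave open whether fluoro, methyl or an amine on this aromatic carbon would give a number closer to that of hydrogen or that of chloro. They also leave open whether the same step would appear in compound 3, since no partner carrying hydrogen in place of its chloro stands among them.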